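The source may report more compounds than this note shows. Statements on the series, on what has been measured and on what is new or still open speak of the compounds shown alone.

Measured compounds:
- compound 1 `Cc1cc(O)c(C(C)C)cc1NC1=NC(=O)S/C1=C\c1ccc(Cl)cc1`: in this assay "not determined" (no result reported)
- compound 2 `COc1ccc(-c2nnc(/N=C3\NC(=O)CS3)o2)cc1`: in this assay 81.8%
- compound 3 `O=C1CS/C(=N/N=C/c2cccnc2)N1`: in this assay "not determined" (no result reported)

Three compounds have been run in a physicochemical assay for inhibition, with a stated time of 3 min (a lower number here means a smaller maximal response, a higher number a larger maximal response), but only one of them returned a number. Compound 2 gives 81.8% in this assay. For compound 1 the outcome is "not determined" (no result reported), and for compound 3 it is likewise "not determined" (no result reported). Compound 3 therefore stands nowhere on the numbers shown: there is no single value for it, and one further compound shares this gap. Nothing can be said about how compound 3 compares with compound 2, because no result exists for compound 3.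

Compound 4 `CC1S/C(=N/N=C/c2cccnc2)NC1=O` is the next compound to be tested. It differs from compound 3 in a single place: methyl in place of hydrogen on a saturated ring carbon. Among the compounds with values here, a change of this size, a methyl in place of hydrogen on a saturated ring carbon, has no measured counterpart among the compounds here, so there is no step to lean on. Within the data shown here, with nothing measured for compound 3, the expectation can rest only on the one number available, that of compound 2 at 81.8%, and on the smallness of the change. The expected step for compound 4 in this assay is therefore none beyond the scatter, in no particular direction.

Compound 4 is estimated at 75%, within a range from 40% to 100%.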

Compound 4, largest response reached (Emax), in percent of the reference or control that the assay uses: 35.8%
Beside the measured number, compound 4's estimate is 39.2 percentage points above it; measured number below the stated range.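

No step can be read from compound 3 to compound 4: in this assay compound 4 gives 35.8% while compound 3 gives "not determined" (no result reported) as its entry. The compounds shown leave open what methyl in place of hydrogen on a saturated ring carbon does to the largest response. No evidence shown here bears on this result.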